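Swapping the oxazolidinone ring for a pyrrolidinone

This account rests on a few compounds, and the source may have more. Where it says the series, first, only, none or still open, it means among the compounds named here.

Compound 1 `O=C1CC(Oc2ncccn2)CN1c1cnn2c1CN(C(=O)Nc1cc(F)c(F)c(F)c1)C(C1CC1)C2`: > 200000 nM
Compound 2 `O=C1OC(c2ccccc2)CN1c1cnn2c1CN(C(=O)Nc1cc(F)c(F)c(F)c1)C(C1CC1)C2`: 7410 nM
Compound 3 `Cc1cnc(C2CC(=O)N(c3cnn4c3CN(C(=O)Nc3cc(F)c(F)c(F)c3)C(C3CC3)C4)C2)s1`: 96200 nM

In a toxicity assay on HepG2 2.2.15 cells (Homo sapiens) for cytotoxicity, read by CellTiter-Glo (on this read-out higher numbers stand for lower toxicity in this test and lower numbers for higher toxicity in this test), compound 1 reaches only the limit of the test, > 200000 nM, so no number is known for it. Of the two numbers that exist, compound 2 stands lowest in this assay with 7410 nM, meaning it is the more toxic of the pair. Compound 3 sits well apart: a 13-fold higher number from compound 2 to compound 3 (1.11 log units; beyond the scatter). The other measured step, an at least 2.0-fold lower number from compound 1 to compound 3 (0.31 log units; beyond the scatter), cannot be sized fully (the limit of > 200000 nM in this assay, at which 1 of the 3 values shown sits).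

Compound 4 `O=C1CC(c2ccccc2)CN1c1cnn2c1CN(C(=O)Nc1cc(F)c(F)c(F)c1)C(C1CC1)C2` differs from compound 2 in one place: 2-oxo-4-phenylpyrrolidin-1-yl in place of 2-oxo-5-phenyl-1,3-oxazolidin-3-yl on an aromatic carbon. Among the compounds with values here, no measured step covers exactly this exchange. The step from compound 2 to compound 3 shows that moving away from the oxazolidinone carrying a phenyl group gave a large rise in this assay, but that step also changed the aromatic group, whereas compound 4 keeps the phenyl. A smaller rise than that is therefore expected for compound 4, a 2.7-fold higher number from compound 2 to compound 4 (0.43 log units; beyond the scatter). The expected value for compound 4 in this assay is 20000 nM, with a range from 5000 nM to 80000 nM.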

Compound 4, half-maximal cytotoxic concentration: 12800 nM
Estimate against measurement, compound 4: 1.6-fold (0.19 log units) above; the measured number falls inside the stated range.
By their numbers in this assay, from the lowest: compounds 2 and 4 (each within the scatter of the next); then compound 3. At a limit, above all of these: compound 1.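

With the phenyl kept, the oxazolidinone and the pyrrolidinone cannot be told apart in this assay: a 1.7-fold higher number from compound 2 to compound 4 (0.24 log units; within the scatter). Among the pyrrolidinone compounds, by contrast, the group on the saturated ring carbon does separate the numbers, and this exchange alone gives a 7.5-fold lower number from compound 3 to compound 4 (0.88 log units; beyond the scatter). The step of an at least 15-fold lower number from compound 1 to compound 4 (1.19 log units; beyond the scatter) starts from a limit and not from a number, so it points the same way but its full size stays unknown: the limit of > 200000 nM in this assay, at which 1 of the 4 values shown sits.

The compounds shown leave open whether this toxicity follows the phenyl itself or would also appear with another carbon ring, such as cyclohexyl, on that saturated ring carbon. They also leave open what an amine or a carboxylic acid on the phenyl would do to the number in this assay.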